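Amino for Hydrogen on Two Related Chloropurine Cores

The source may report more compounds than this note shows. Statements on the series, on what has been measured and on what is new or still open speak of the compounds shown alone.

The set has three measured compounds and one that is still to be measured. Compound 1 `ClCc1ccc(Cn2cnc3c(Cl)ncnc32)cc1` carries a core that is left unsubstituted at the carbon of interest; in a functional assay on A498 cells (Homo sapiens) for cytotoxicity, read by sulforhodamine B assay, with a stated time of 48 h (on this read-out lower numbers stand for stronger inhibition of growth and higher numbers for weaker inhibition of growth), compound 1 gives 12900 nM. Compound 2 `Nc1nc(Cl)c2ncn(Cc3ccc(CCl)cc3)c2n1` differs from compound 1 in one place, (amino in place of hydrogen on an aromatic carbon), and in this assay compound 2 gives 21900 nM. The step that this change made is a 1.7-fold higher number from compound 1 to compound 2 (0.23 log units; within the scatter).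

Compound 3 `ClCc1ccccc1Cn1cnc2c(Cl)ncnc21` is built from the same atoms as compound 1, joined differently; the difference between the two cores is not broken down here. In this assay compound 3 gives 17400 nM, which sits within the scatter of both compound 1 and compound 2, so no order among the three can be read from these values.

Compound 4 `Nc1nc(Cl)c2ncn(Cc3ccccc3CCl)c2n1` is not yet measured. It stands to compound 3 as compound 2 stands to compound 1: amino in place of hydrogen on an aromatic carbon. The surroundings of the place are described in the same words in both cases, so this is the same change, now on the core of compound 3.

Because the same change gave a 1.7-fold higher number from compound 1 to compound 2 (0.23 log units; within the scatter), and because compound 3 starts from 17400 nM, compound 4 is expected to give a step of about a 1.6-fold higher number from compound 3 to compound 4 (0.21 log units; within the scatter) in this assay. Compound 4 is therefore estimated at 28000 nM, with a likely range from 14000 nM to 56000 nM.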

Compound 4, concentration for 50% growth inhibition: 20400 nM
Compound 4: middle estimate off by 1.4-fold (0.14 log units), on the high side; measured number inside the range.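

In this assay the exchange of amino for hydrogen on an aromatic carbon gives a 1.2-fold higher number from compound 3 to compound 4 (0.07 log units; within the scatter) on the core of compound 3, and the comparison with the core of compound 1 reads as follows: the same change on two cores in this assay, a 1.7-fold higher number (0.23 log units; within the scatter) from compound 1 to compound 2 and a 1.2-fold higher number (0.07 log units; within the scatter) from compound 3 to compound 4, 1.4-fold (0.16 log units) apart, within the scatter of two such steps. So far as these two pairs go, the change carries over from one core to the other, in the sense that it leaves a small step on both and the two steps cannot be told apart. This does not show that the amino group has any effect of its own on growth inhibition, since neither step stands clear of the scatter, and two pairs with such small steps give no rule that could be taken to a further core.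

The compounds shown leave open whether a methylamino group, a dimethylamino group or a methoxy group on the same aromatic carbon would give a step beyond the scatter on either core. They also leave open what a primary amine or a thiol in place of the chloro group would do, and whether the agreement between the two cores would still hold with such groups.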